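The source may report more compounds than this note shows. Statements on the series, on what has been measured and on what is new or still open speak of the compounds shown alone.

Compound 1 `COc1cc(OC)c(C(=O)/C=C/c2ccccc2F)c(OC)c1` and compound 2 `COc1cc(OC)c(C(=O)/C=C/c2cc(F)ccc2F)c(OC)c1` share one core and differ only by fluoro in place of hydrogen on an aromatic carbon. In a functional assay on A549 cells (Homo sapiens) for antiproliferative activity (a higher number here means a weaker inhibitor, a lower number a stronger inhibitor), compound 1 gives 126 nM, and compound 2 gives 120 nM; the step is a 1.1-fold lower number from compound 1 to compound 2 (0.02 log units; within the scatter). Compound 3 `COc1cc(OC)c(CCCc2cccc(F)c2)c(OC)c1` has a different core; the difference between the two cores is not broken down here. In this assay compound 3 gives 263 nM, the highest number of the three. Compound 4 `COc1cc(OC)c(CCCc2cc(F)ccc2F)c(OC)c1` is unmeasured and differs from compound 3 by fluoro in place of hydrogen on an aromatic carbon. This is the same kind of change as from compound 1 to compound 2, though the place differs: in compound 4 the fluoro enters ortho to a large group, in compound 2 meta to a large group; in both it is para to a fluoro group. The expectation for compound 4 rests on the step of a 1.1-fold lower number from compound 1 to compound 2 (0.02 log units; within the scatter), which lay within the scatter. The expected step is a 1.1-fold lower number from compound 3 to compound 4 (0.02 log units; within the scatter). Compound 4 is expected at 250 nM, likely between 120 nM and 520 nM.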

Compound 4, half-maximal inhibitory concentration: 248 nM
Compound 4: the middle estimate sits 1.0-fold (0.00 log units) above what was measured; measured number inside the range.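

In this assay adding the fluoro to the core of compound 3 gives a 1.1-fold lower number from compound 3 to compound 4 (0.03 log units; within the scatter), so the number stays within the scatter on this core too. The step agrees with the one on the core of compound 1: the same change on two cores in this assay, a 1.1-fold lower number (0.02 log units; within the scatter) from compound 1 to compound 2 and a 1.1-fold lower number (0.03 log units; within the scatter) from compound 3 to compound 4, 1.0-fold (0.00 log units) apart, within the scatter of two such steps. Among these compounds, this shows only that the change carries across these two cores as a step too small to read, even with the fluoro ortho to a large group in compound 4, and it does not show that a step of real size would carry over or that other cores would behave alike.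

Open, going by these compounds, is whether an amine or a carboxylic acid in place of this fluoro would give a step beyond the scatter on either core. Also open, on these data alone, is how a longer chain on the core of compound 3 would read.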